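Adding a Second Chloro to the Core of Compound 3

The source may report more compounds than this note shows. Statements on the series, on what has been measured and on what is new or still open speak of the compounds shown alone.

Among the measured compounds shown here, compound 3 `O=C1CSC(c2ccccc2Cl)N1CCN1CCCCC1` gives 94% in an ADME assay on Vero cells (Chlorocebus sabaeus) for cytotoxicity, read by neutral red uptake, tested at 98 ug/mL (on this read-out lower numbers stand for a stronger effect and higher numbers for a weaker effect at the one concentration tested), the highest of the three numbers measured so far. Compound 2 `O=C1CSC(c2ccc(F)cc2)N1CCN1CCCCC1` gives 87%, within the scatter of compound 3, while compound 1 `O=C1CSC(c2ccc(Cl)cc2)N1CCN1CCCCC1` gives 74%, beyond it. Compound 4 `O=C1CSC(c2c(Cl)cccc2Cl)N1CCN1CCCCC1` differs from compound 3 by chloro in place of hydrogen on an aromatic carbon. For the measured compounds named here, no measured step adds a group to the aromatic ring; the nearest guides are a number 13 percentage points higher from compound 1 to compound 2 (beyond the scatter) and a number 20 percentage points higher from compound 1 to compound 3 (beyond the scatter), both modest, and a number 7 percentage points higher from compound 2 to compound 3 (within the scatter). Compound 3 already lies high on this read-out, toward a weaker effect. The step of a number 4 percentage points lower from compound 3 to compound 4 (within the scatter) is therefore expected to stay within the scatter. Compound 4 is estimated at 90%, in the range 75% to 100%.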

Compound 4, a percentage reported as activity, at one concentration (the size of the read-out at that concentration, not a potency): 76%
Compound 4: the middle estimate sits 14 percentage points above what was measured; the measured number falls inside the stated range.
By their numbers in this assay, from the lowest: compounds 1 and 4 (each within the scatter of the next); then compounds 2 and 3 (each within the scatter of the next).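

Placing chloro on this aromatic carbon in place of hydrogen, ortho to a large group, gives a number 18 percentage points lower from compound 3 to compound 4 (beyond the scatter) in this assay, a modest move toward a stronger effect. The earlier steps shown here only exchanged one substituted ring for another, whereas this one shows that adding a single chlorine atom to the ring of compound 3 can shift the read-out by itself. No measurement available here explains this shift.

Going by these compounds, it remains open whether a methyl or a methoxy group at this position would move the number in the same direction. The effect of an amine there is equally unresolved.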